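The source may report more compounds than this note shows. Statements on the series, on what has been measured and on what is new or still open speak of the compounds shown alone.

Two compounds with a shared core, `COc1cc(Oc2cccc(Nc3ccccc3)c2)cc(OC)c1CN[C@H](C)c1ccccc1` for compound 1 and `COc1ccc([C@@H](C)NCc2c(OC)cc(Oc3cccc(Nc4ccccc4)c3)c(OC)c2OC)cc1` for compound 2, have been tested in a functional assay on HT-29 cells (Homo sapiens) for inhibition, read by MTT assay, with a stated time of 72 h; a lower number here means a stronger inhibitor, a higher number a weaker inhibitor. Compound 1 gives 5120 nM there, the higher of the two numbers; compound 2 gives 1630 nM, and the gap between them lies beyond the usual scatter. Compound 3, `COc1cc(Oc2cccc(Nc3ccccc3)c2)cc(OC)c1CNCc1ccc(Br)cc1`, has not yet been measured. It differs from compound 1 in one place: 4-bromobenzyl in place of 1-phenylethyl on an amine nitrogen. Nothing measured here shows what this exchange does, so the step is expected to be small, a 1.3-fold lower number from compound 1 to compound 3 (0.11 log units; within the scatter), not beyond the scatter in either direction. Compound 3 is therefore estimated at 4000 nM, within a range from 1500 nM to 12000 nM.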

Compound 3, half-maximal inhibitory concentration: 3060 nM
Compound 3: middle estimate off by 1.3-fold (0.12 log units), on the high side; the range from low to high includes it.
By their numbers in this assay, from the lowest: compounds 2, 3 and 1 (each within the scatter of the next, the first and the last beyond it).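

In this assay, 4-bromobenzyl in place of 1-phenylethyl on an amine nitrogen gives a 1.7-fold lower number from compound 1 to compound 3 (0.22 log units; within the scatter), so this position accepts the exchange without a change beyond the scatter. The exchange removes the defined stereocentre and adds a bromine in a single step, and the two cannot be separated here. No measurement here explains the result.

Going by these compounds, whether a plain benzyl or a 4-chlorobenzyl group would fit as well remains open. So does the effect of the 4-bromobenzyl group on the core of compound 2.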